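Dropping the Carboxy Group from Compound 2

The source may hold more compounds than are shown below. What is called first, only, known or untested is meant among the compounds shown, and "the series" means these compounds.

Compound 1 `CCCCCCCOc1ccc(CCC(N)(CO)CO)cc1` gives 0.014 mg/kg in a functional assay on the whole organism (spleen, spleen) with Rattus norvegicus as the target; on this read-out lower numbers stand for an effect already at smaller amounts and higher numbers for an effect only at larger amounts of compound. Compound 2 `CCCCCCCCc1ccc(CCC(N)(CO)C(=O)O)cc1` reaches in this assay only the limit of > 10 mg/kg, a boundary of the measurement rather than a number, as the limit of > 10 mg/kg in this assay, at which 1 of the 2 values shown sits, records. Compound 3 `CCCCCCCCc1ccc(CCC(N)CO)cc1` differs from compound 2 by one change: hydrogen in place of carboxy on a saturated chain carbon bound to an amine nitrogen and two saturated chain carbons. Among the compounds with values here, no measured pair shows this change, so its effect must be estimated; a move toward an effect at smaller amounts is expected, an at least 10-fold lower number from compound 2 to compound 3 (1.00 log units; beyond the scatter). Compound 3 is therefore expected to give 1 mg/kg in this assay, with a range from 0.1 mg/kg to 10 mg/kg.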

Compound 3, dose for 50% inhibition: > 10 mg/kg
Compound 3 ended at the assay's limit; the forecaster's own chance of this, stated with the estimate: 30%; middle value at least 10-fold (1.00 log units) away from the limit.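

Compound 2 gives > 10 mg/kg, a limit and not a number. Within the data shown here, compound 3 gives > 10 mg/kg, also a limit, and no step between these two compounds can be read. As far as these compounds go, how much hydrogen in place of carboxy changes the effect stays open.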